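Methoxy in place of trifluoromethyl: stability notes

The source may report more compounds than this note shows. Statements on the series, on what has been measured and on what is new or still open speak of the compounds shown alone.

In an ADME assay on S9 fraction from liver (Homo sapiens) for metabolic stability, with a stated time of 1 h (on this read-out higher numbers stand for a more stable compound and lower numbers for a less stable compound), compound 1 (`N#Cc1cnc(NCc2cnccc2C(F)(F)F)cc1NC[C@H]1CC[C@H](O)CC1`) gives 32% and compound 2 (`N#Cc1cnc(NCc2cncnc2C(F)(F)F)cc1N[C@H]1CC[C@@H](O)CC1`) gives 76% as the highest of the two numbers, a gap beyond the scatter. Compound 3 (`COc1ncncc1CNc1cc(N[C@H]2CC[C@@H](O)CC2)c(C#N)cn1`) carries methoxy in place of trifluoromethyl on an aromatic carbon. Going by the values given here, no measured step covers this change, so the expectation rests on the structural change alone: a moderate fall beyond the scatter is expected, estimated as a number 16 percentage points lower from compound 2 to compound 3 (beyond the scatter) in this read-out. Compound 3 is expected at 60% with an estimated range from 35% to 85% in this read-out.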

Compound 3, percent of the compound remaining: 88%
For compound 3 the middle estimate is 28 percentage points below the measured one; measured number above the stated range.
By their numbers in this assay, from the lowest: compound 1; then compound 2; then compound 3.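

Replacing trifluoromethyl with methoxy on an aromatic carbon next to the ring nitrogen gives a number 12 percentage points higher from compound 2 to compound 3 (beyond the scatter) in this assay, so trifluoromethyl is not needed at this place to hold stability on this read-out. This is the only single-place step among the compounds shown, as compound 1 differs from compound 2 in more than one place. Nothing measured here accounts for the rise.

As far as these compounds go, whether an amine or an ethoxy group at this place would hold the number remains open. So does whether the same change would give a similar step in compound 1 .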